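The compounds below may be only part of what the source reports. "The series", "measured", "known", "first", "only" and "open" are said of these compounds alone.

Working notes on the series. Three compounds share one core and differ only in the aryl group on an oxygen on a saturated carbon. In a functional assay with Homo sapiens as the target (a lower number here means a stronger inhibitor, a higher number a weaker inhibitor), compound 1 `CC(C)[C@H](NC(=O)COc1cccc2ccccc12)C(=O)N[C@@H](CC(=O)O)C(=O)COc1ccccc1` gives 11200 nM, which is the low end of the three numbers, with both other compounds within the usual scatter of it. Compound 2 `CC(C)[C@H](NC(=O)COc1cccc2ccccc12)C(=O)N[C@@H](CC(=O)O)C(=O)COc1cccc2ccccc12` gives 19000 nM in this assay, and compound 3 `CC(C)[C@H](NC(=O)COc1cccc2ccccc12)C(=O)N[C@@H](CC(=O)O)C(=O)COc1cc(F)ccc1F` gives 19700 nM. The steps are a 1.7-fold higher number from compound 1 to compound 2 (0.23 log units; within the scatter), a 1.8-fold higher number from compound 1 to compound 3 (0.25 log units; within the scatter) and a 1.0-fold higher number from compound 2 to compound 3 (0.02 log units; within the scatter); none of them reaches beyond the scatter.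

Compound 4 `CC(C)[C@H](NC(=O)COc1cccc2ccccc12)C(=O)N[C@@H](CC(=O)O)C(=O)COc1c(F)cc(F)cc1F` is not yet measured in this assay. It differs from compound 1 by 2,4,6-trifluorophenyl in place of phenyl on an oxygen on a saturated carbon. The step that bears most directly on it is the fluorinated phenyl of compound 3, a 1.8-fold higher number from compound 1 to compound 3 (0.25 log units; within the scatter), and the bulkier aryl of compound 2, a 1.7-fold higher number from compound 1 to compound 2 (0.23 log units; within the scatter), points the same way; both are small. For compound 4 a step of about a 1.5-fold higher number from compound 1 to compound 4 (0.18 log units; within the scatter) is therefore expected, a slightly higher number that stays within the scatter, and the estimate for compound 4 is 17000 nM with a range from 7000 nM to 40000 nM.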

Compound 4, half-maximal inhibitory concentration: 14900 nM
Beside the measured number, compound 4's estimate is 1.1-fold (0.06 log units) above it, within the range that was stated.
By their numbers in this assay, from the lowest: compounds 1, 4, 2 and 3 (each within the scatter of the next).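

In this assay, adding fluorine to the phenyl group at this position gives only a small change, a 1.3-fold higher number from compound 1 to compound 4 (0.12 log units; within the scatter), and it stays within the scatter. The 2,4,6-trifluorophenyl group also stays within the scatter of the other two aryl groups, with a 1.3-fold lower number from compound 3 to compound 4 (0.12 log units; within the scatter) and a 1.3-fold lower number from compound 2 to compound 4 (0.11 log units; within the scatter), so all four aryl groups on this oxygen now read as one level and this change separates none of them. Nothing measured alongside these numbers bears on the result or offers an explanation for it.

Going by these compounds, all four groups on this oxygen are aromatic carbon rings, so it remains open whether an amine or a saturated alkyl chain in place of the aryl group would move the number beyond the scatter. On these data alone, whether changes elsewhere on the shared core would do so also remains open.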